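Does Fluoro Cost Compound 3 Its Lead?

The compounds below may be only part of what the source reports. "The series", "measured", "known", "first", "only" and "open" are said of these compounds alone.

Of the compounds shown here, three sharing one core have been measured in a functional assay on HCT-116 cells (Homo sapiens) for cytotoxicity, read by MTT assay, with a stated time of 72 h; on this read-out lower numbers stand for stronger inhibition and higher numbers for weaker inhibition. Compound 1 `Nc1ccccc1NC(=O)c1ccc(NC(=S)NCc2ccc(Cl)nc2)cc1` gives 6100 nM. Compound 2 `Nc1ccccc1NC(=O)c1ccc(NC(=S)NCc2ccccc2F)cc1` gives 6300 nM, and a 1.0-fold higher number from compound 1 to compound 2 (0.01 log units; within the scatter) shows that these two cannot be told apart. Compound 3 `Nc1ccccc1NC(=O)c1ccc(NC(=S)NCc2cccnc2)cc1` has the lowest number of the three at 1000 nM, and its steps to both others lie beyond the scatter.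

Compound 4 `Nc1ccccc1NC(=O)c1ccc(NC(=S)NCc2cncc(F)c2)cc1` turns pyridin-3-yl into 5-fluoropyridin-3-yl, with fluoro in place of hydrogen on an aromatic carbon.

The nearest evidence runs in reverse. Putting hydrogen in place of chloro on an aromatic carbon gave a 6.1-fold lower number from compound 1 to compound 3 (0.79 log units; beyond the scatter), a modest step. Putting pyridin-3-yl in place of 2-fluorophenyl gave a 6.3-fold lower number from compound 2 to compound 3 (0.80 log units; beyond the scatter), also modest. Both compounds carrying a halogen therefore sit higher than compound 3, which hints that adding one may raise the number. Among the measured compounds shown here, still, no measured compound carries fluoro on the nitrogen-containing ring, and chloro is a different atom, so this is weak guidance. A somewhat smaller upward move in this assay is expected, estimated as a 2.0-fold higher number from compound 3 to compound 4 (0.30 log units; within the scatter). Compound 4 is expected at 2000 nM, with an estimated range of 700 nM to 6000 nM.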

Compound 4, half-maximal inhibitory concentration: 15000 nM
For compound 4 the middle estimate is 7.5-fold (0.88 log units) below the measured one; measured number outside the range, above it.
By their numbers in this assay, from the lowest: compound 3; then compounds 1 and 2 (each within the scatter of the next); then compound 4.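

In this assay, this position on the pyridin-3-yl group, on an aromatic carbon two atoms from the ring nitrogen, proves highly sensitive: a single added fluorine atom gives a 15-fold higher number from compound 3 to compound 4 (1.18 log units; beyond the scatter) and counts as a large step. The change also carries compound 4 past both earlier halogen-bearing compounds, with a 2.4-fold higher number from compound 2 to compound 4 (0.38 log units; beyond the scatter) and a 2.5-fold higher number from compound 1 to compound 4 (0.39 log units; beyond the scatter), so the 5-fluoropyridin-3-yl group does worse here than either the 2-fluorophenyl or the 6-chloropyridin-3-yl group, and unsubstituted compound 3 remains the clear lowest of the four. No measurement shown offers a reason for the size of this jump.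

The compounds shown cannot tell whether the rise belongs to fluoro itself or would follow any group on this carbon, and a methyl group or an amine placed there would help separate those two readings. On these data alone, whether fluoro on another carbon of the same ring would give a step of similar size also remains open.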